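The source may report more compounds than this note shows. Statements on the series, on what has been measured and on what is new or still open speak of the compounds shown alone.

Going by the values given here, compound 2 `CC(C)Oc1cncc(C2=CC3CNCC(C2)C3)c1` gives 86% in a functional assay on synaptosomes from brain (strain Sprague-Dawley) for agonist activity at Nicotinic acetylcholine receptor alpha6/alpha3/beta2/beta3 (Rattus norvegicus) (on this read-out higher numbers stand for larger maximal responses and lower numbers for smaller maximal responses), the higher of the two numbers measured so far; compound 1 `C1=C(c2cncc(Oc3ccccc3)c2)CC2CNCC1C2` gives 57% in this assay, and the step of a number 29 percentage points higher from compound 1 to compound 2 (beyond the scatter) came with isopropyl in place of phenyl on an oxygen on an aromatic ring. Compound 3 `CC(C)Oc1cncc(C2=CC3CC(C2)CN(C)C3)c1` differs from compound 2 by methyl in place of hydrogen on an amine nitrogen in a ring. Among the compounds with values here, no measured step touches that amine nitrogen, so the one known step offers no guide to the size or direction of the change. Compound 3 is expected to show 70% in this assay, somewhere between 35% and 100%, an estimated step of a number 16 percentage points lower from compound 2 to compound 3 (beyond the scatter).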

Compound 3, largest response reached (reported as percent of maximum), in percent of the reference or control that the assay uses: 63%
Compound 3: middle estimate off by 7 percentage points, on the high side; low and high end bracket the measured number.
By their numbers in this assay, from the lowest: compounds 1 and 3 (each within the scatter of the next); then compound 2.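

The ring amine nitrogen now has a measured step of its own: in this assay methyl in place of hydrogen gives a number 23 percentage points lower from compound 2 to compound 3 (beyond the scatter) with the rest of the molecule unchanged. So the response depends on this nitrogen as well as on the group on the oxygen, and even one added carbon there counts. Nothing measured here accounts for the drop. Going by these compounds, whether a longer or bulkier group on this nitrogen, such as ethyl or benzyl, would lower the response further remains open. So does whether methyl there would have a similar effect with phenyl on the oxygen.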